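Oxazole ketones: aryl-to-fluoro replacement on the five-membered ring

The source may hold more compounds than are shown below. What is called first, only, known or untested is meant among the compounds shown, and "the series" means these compounds.

Measured so far:
compound 1 `COC(=O)c1ccccc1-c1cnc(C(=O)CCCCCCc2ccccc2)o1` — 60 nM
compound 2 `COC(=O)c1cccc(-c2cnc(C(=O)CCCCCCc3ccccc3)o2)c1` — 12 nM
compound 3 `NC(=O)c1ccc(-c2cnc(C(=O)CCCCCCc3ccccc3)o2)cc1` — 10 nM

In an assay (Rattus norvegicus) for inhibition of Fatty-acid amide hydrolase 1 (Homo sapiens) (on this read-out lower numbers stand for stronger inhibition and higher numbers for weaker inhibition), compound 3 gives the lowest of the three numbers. Compound 2 lies within the scatter of compound 3, so no order between them is claimed; compound 1 gives a higher number than compound 3, beyond the scatter.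

Compound 4 `O=C(CCCCCCc1ccccc1)c1ncc(F)o1` differs from compound 3 in one place: fluoro in place of 4-carbamoylphenyl on an aromatic carbon. For the measured compounds named here, no measured pair in this set shows such a change. The step from compound 3 to compound 4 is expected to be a clear rise in the number, beyond the scatter, because compound 3 gives 10 nM with the 4-carbamoylphenyl group present, and compound 4 keeps only the fluoro in that place.

Compound 4 is estimated at 300 nM, with a range from 60 nM to 1500 nM, a step of a 30-fold higher number from compound 3 to compound 4 (1.48 log units; beyond the scatter).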

Compound 4, inhibition constant: 30 nM
Beside the measured number, compound 4's estimate is 10-fold (1.00 log units) above it; the measured number lies below the stated range.
By their numbers in this assay, from the lowest: compounds 3 and 2 (each within the scatter of the next); then compounds 4 and 1 (each within the scatter of the next).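

In this assay, fluoro in place of 4-carbamoylphenyl, on the aromatic carbon next to the ring oxygen, gives a 3.0-fold higher number from compound 3 to compound 4 (0.48 log units; beyond the scatter), a modest step. Inhibition at this position therefore survives the loss of the whole aryl group, with one heavy atom standing in for nine. Nothing available accounts for the size of this step.

Still open, from the compounds shown here alone, is where hydrogen, chloro or a nitrile at this position would fall relative to fluoro. Also open, going by these compounds, is whether a carboxylic acid in place of the carbamoyl group would move the number from that of compound 3.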